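Pyridin-4-yl Enters a Compound Standing at the Limit

The source may report more compounds than this note shows. Statements on the series, on what has been measured and on what is new or still open speak of the compounds shown alone.

In a functional assay on BT-474 cells (Homo sapiens) for antiproliferative activity, read by MTT assay, with a stated time of 72 h (a lower number here means a stronger inhibitor, a higher number a weaker inhibitor), compound 1 (`CC(Nc1ncnc2ncc(-c3cnn(C4CCNCC4)c3)cc12)c1c(Cl)ccc(F)c1Cl`) gives 13500 nM as a measured number. Compound 3 (`C#Cc1cccc(Nc2ncnc3ccc(-c4cnn(C)c4)cc23)c1`) gives 5680 nM in this assay and differs from the others in more than one place. Compound 2 (`CC(Nc1ncnc2ncc(-c3cnn(C)c3)cc12)c1c(Cl)ccc(F)c1Cl`) gives > 100000 nM in this assay and that value is a limit, not a number (the limit of > 100000 nM in this assay, at which 1 of the 3 values shown sits). Among the measured compounds shown here, the only measured step here is an at least 7.4-fold higher number from compound 1 to compound 2 (0.86 log units; beyond the scatter) and it comes with methyl in place of piperidin-4-yl on an aromatic nitrogen.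

The next structure, compound 4 (`CC(Nc1ncnc2ncc(-c3cnn(C)c3)cc12)c1ccncc1`), keeps that methyl. It carries pyridin-4-yl in place of 2,6-dichloro-3-fluorophenyl on a saturated chain carbon bound to a nitrogen on an aromatic ring and a saturated chain carbon. For the measured compounds named here, no measured step touches that place, so the step seen at the aromatic nitrogen, an at least 7.4-fold higher number from compound 1 to compound 2 (0.86 log units; beyond the scatter) and no more, is only a loose guide. With nothing pointing either way, no shift beyond the scatter is expected in this assay from this change. The expected move is a number no higher from compound 2 to compound 4 (the limit leaves the size open) and it is an estimate with a wide margin. The estimate for compound 4 is 100000 nM with an expected range from 30000 nM to 200000 nM and the assay may well report only a limit.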

Compound 4, half-maximal inhibitory concentration: > 100000 nM
Compound 4: only a limit was reported; the forecaster's own chance of this, stated with the estimate: 65%; the middle value lies on the limit itself.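

No step can be read from compound 2 to compound 4, because both values are limits and not numbers: the limit of > 100000 nM in this assay, at which 2 of the 4 values shown sit.

The compounds shown leave open whether pyridin-4-yl in place of 2,6-dichloro-3-fluorophenyl changes the antiproliferative effect at all, and how that change would act with piperidin-4-yl on the aromatic nitrogen, as in compound 1.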